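A few compounds are considered here, and "the series" means these few. Any claim that something is new, unique, unknown or untested is made for them only; others in the source may bear on it.

In an ADME assay on MDCK cells (Canis lupus familiaris) for cytotoxicity, read by MTT assay, with a stated time of 3 days (on this read-out lower numbers stand for higher toxicity in this test and higher numbers for lower toxicity in this test), compound 1 `CC1(C)C[C@H](O)C[C@](C)(CNc2cccc(C(F)(F)F)c2)C1` gives 7800 nM, and compound 3 `CC1(C)C[C@H](O)C[C@](C)(CNc2cc(F)cc(S(N)(=O)=O)c2)C1` gives 55000 nM. Compound 2 `CC1(C)C[C@H](O)C[C@](C)(CNc2cccc(S(N)(=O)=O)c2)C1` stands at > 100000 nM in this assay, which is a limit of the test rather than a number (the limit of > 100000 nM in this assay, at which 1 of the 3 values shown sits). The change to compound 4 `Cc1ccc(NC[C@@]2(C)C[C@@H](O)CC(C)(C)C2)cc1S(N)(=O)=O` is methyl in place of hydrogen on an aromatic carbon. For the measured compounds named here, two measured steps bear on it: the sulfamoyl step an at least 12-fold higher number from compound 1 to compound 2 (1.10 log units; beyond the scatter) and the fluoro step an at least 1.8-fold lower number from compound 2 to compound 3 (0.25 log units; that floor lies within the scatter), the second being the closer analogue, a small ring substituent added to the same core. A step of an at least 1.1-fold lower number from compound 2 to compound 4 (0.04 log units; that floor lies within the scatter) is therefore expected, so compound 4 is estimated at 90000 nM, between 30000 nM and 250000 nM, in this assay.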

Compound 4, half-maximal cytotoxic concentration: 81500 nM
Estimate against measurement, compound 4: 1.1-fold (0.04 log units) above; the measured number falls inside the stated range.
By their numbers in this assay, from the lowest: compound 1; then compounds 3 and 4 (each within the scatter of the next). At a limit, above all of these: compound 2.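

The earlier compounds shown here showed only fluoro as an added ring substituent; here a methyl, ortho to a sulfamoyl group and para to a large group, gives an at least 1.2-fold lower number from compound 2 to compound 4 (0.08 log units; that floor lies within the scatter) in this assay. So a carbon substituent at this place brings no step shown to lie beyond the scatter. Its true size stays unknown because compound 2 has only a limit and not a number: the limit of > 100000 nM in this assay, at which 1 of the 4 values shown sits.

On these data alone, whether a longer chain such as ethyl, or an amine, at this place would give a step beyond the scatter remains open. So does whether methyl would behave alike elsewhere on the ring.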